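Methyl to fluoro in the series: working notes

The compounds below may be only part of what the source reports. "The series", "measured", "known", "first", "only" and "open" are said of these compounds alone.

Measured in a functional assay on RAW264.7 cells (Mus musculus) for inhibition, with stated times of 2 h and 24 h; on this read-out higher numbers stand for weaker inhibition and lower numbers for stronger inhibition:
- compound 1 `COc1ccc(C(O)C2c3cc(OC)cc(OC)c3[C@@H](c3ccc(OC)cc3)[C@@H]2c2cc(OC)cc(OC)c2)cc1`: > 200000 nM, a limit of the assay
- compound 2 `COc1ccc([C@@H]2c3c(OC)cc(OC)cc3C(C(O)c3ccc(C)cc3)[C@H]2c2cc(OC)cc(OC)c2)cc1`: 26500 nM

Among the measured compounds shown here, compound 2, at 26500 nM, holds the only actual number so far. For compound 1 the result is only a limit, (the limit of > 200000 nM in this assay, at which 1 of the 2 values shown sits).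

Compound 3 `COc1ccc([C@@H]2c3c(OC)cc(OC)cc3C(C(O)c3ccc(F)cc3)[C@H]2c2cc(OC)cc(OC)c2)cc1` carries fluoro in place of methyl on an aromatic carbon, para to a large group: fluoro in place of methyl on an aromatic carbon.

For the measured compounds named here, one measured step bears on this, at the same aromatic carbon: an at least 7.5-fold lower number from compound 1 to compound 2 (0.87 log units; beyond the scatter). Going by the values given here, that step shows that the group on this carbon can move the number in this assay, but no fluoro compound has been measured, so it gives only weak guidance on direction. A small move toward a higher number is expected, most likely not beyond the scatter. The expected step is a 1.5-fold higher number from compound 2 to compound 3 (0.18 log units; within the scatter). For compound 3 the estimated value is 40000 nM, with an expected range from 14000 nM to 130000 nM.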

Compound 3, half-maximal inhibitory concentration: > 200000 nM
Compound 3 was reported as a limit (the forecaster's own chance of this, stated with the estimate: 20%); middle value at least 5.0-fold (0.69 log units) away from the limit.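

Fluoro in place of methyl on this aromatic carbon, para to a large group, gives an at least 7.5-fold higher number from compound 2 to compound 3 (0.87 log units; beyond the scatter) in this assay, so the exchange of one heavy atom here is enough to lose a readable number. Methoxy and fluoro on this carbon both end at a limit of the assay, which leaves methyl as the only one of the three groups with an actual number: the limit of > 200000 nM in this assay, at which 2 of the 3 values shown sit. The step between those two limit compounds cannot be read, so methoxy and fluoro cannot be ordered against each other.

Three groups on one carbon do not show what the number at this position follows. Chloro, ethyl or an amine at the same place would show whether methyl stands alone in giving a readable number.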